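This account rests on a few compounds, and the source may have more. Where it says the series, first, only, none or still open, it means among the compounds named here.

Compound 1 `Cc1ccc(S(=O)(=O)/N=C(/CCNC2=CC(=O)c3ccccc3C2=O)Nc2cccc(C)c2)cc1` in a functional assay on MCF7 cells (Homo sapiens) for cytotoxicity, read by MTT assay, with a stated time of 48 h (a lower number here means a stronger inhibitor, a higher number a weaker inhibitor), gives 8120 nM, the highest of the two numbers measured in this series. Within the data shown here, compound 2 `Cc1ccc(S(=O)(=O)/N=C(/CCNC2=CC(=O)c3ccccc3C2=O)NCc2ccccc2)cc1` in this assay gives 3630 nM, and the step of a 2.2-fold lower number from compound 1 to compound 2 (0.35 log units; beyond the scatter) is the only measured step that bears on the change considered here. Compound 3 `Cc1ccc(S(=O)(=O)/N=C(/CCNC2=CC(=O)c3ccccc3C2=O)NC2CCCCC2)cc1` differs from compound 1 by cyclohexyl in place of 3-methylphenyl on an amine nitrogen. Because the earlier step of a 2.2-fold lower number from compound 1 to compound 2 (0.35 log units; beyond the scatter) also replaced the 3-methylphenyl on the amine nitrogen, a modest lower number is expected. Compound 3 is estimated at 4200 nM, with a range of 1800 nM to 9500 nM. The expected step is a 1.9-fold lower number from compound 1 to compound 3 (0.29 log units; within the scatter).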

Compound 3, half-maximal inhibitory concentration: 7580 nM
Beside the measured number, compound 3's estimate is 1.8-fold (0.26 log units) below it; low and high end bracket the measured number.
By their numbers in this assay, from the lowest: compound 2; then compounds 3 and 1 (each within the scatter of the next).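

In this assay, cyclohexyl on the amine nitrogen does not separate from 3-methylphenyl, with a 1.1-fold lower number from compound 1 to compound 3 (0.03 log units; within the scatter), so exchanging the aromatic ring for a non-aromatic one registers no change here. Benzyl now stands apart from cyclohexyl as well, with a 2.1-fold higher number from compound 2 to compound 3 (0.32 log units; beyond the scatter), so the lower number goes with benzyl in compound 2 and not with the loss of 3-methylphenyl as such, compound 3 being the case against that reading. Nothing on hand accounts for these steps. Still open, from the compounds shown here alone, is whether a longer chain, such as phenethyl, or a benzyl carrying a methyl group on its ring would hold or extend the modest step seen with compound 2.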